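The compounds below may be only part of what the source reports. "The series", "measured", "known", "first", "only" and "open" are said of these compounds alone.

Of the compounds shown here, three built on one shared core have been measured in a functional assay on A549 cells (Homo sapiens) for antiproliferative activity, read by MTT assay, with a stated time of 48 h; on this read-out higher numbers stand for weaker inhibition of growth and lower numbers for stronger inhibition of growth. Compound 3 `CCN(Cc1ccc(C(=O)NO)cc1)c1ncc(-c2ccc(C)cc2)s1` gives 2700 nM, the lowest of the three numbers. Compound 2 `CCCCCN(Cc1ccc(C(=O)NO)cc1)c1ncc(-c2ccc(C)cc2)s1` gives 9140 nM, and compound 1 `Cc1ccc(OCCCN(Cc2ccc(C(=O)NO)cc2)c2ncc(-c3ccc(C)cc3)s2)cc1` gives 32500 nM. Putting hydrogen in place of propyl shows a 3.4-fold lower number from compound 2 to compound 3 (0.53 log units; beyond the scatter), the larger replacement by hydrogen shows a 12-fold lower number from compound 1 to compound 3 (1.08 log units; beyond the scatter), and the step between the two larger groups shows a 3.6-fold lower number from compound 1 to compound 2 (0.55 log units; beyond the scatter). Among these three, every move to a smaller group went with a lower number.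

Compound 4 `Cc1ccc(-c2cnc(N(Cc3ccc(C(=O)NO)cc3)C(C)C)s2)cc1` differs from compound 3 by methyl in place of hydrogen on a saturated chain carbon bound to a nitrogen on an aromatic ring and a saturated chain carbon, so ethyl becomes isopropyl. The measured steps all concern how much carbon sits on this part of the molecule, and each addition went with a higher number; a single methyl is the smallest addition considered here. The expected step is therefore a 1.6-fold higher number from compound 3 to compound 4 (0.19 log units; within the scatter), a slight rise that may not clear the scatter. Compound 4 is estimated at 4200 nM, with a range from 1800 nM to 9500 nM.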

Compound 4, concentration for 50% growth inhibition: 3830 nM
The estimate for compound 4 lay 1.1-fold (0.04 log units) above the measured number, and the stated range covers the measured number.
By their numbers in this assay, from the lowest: compounds 3 and 4 (each within the scatter of the next); then compound 2; then compound 1.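

In this assay, adding one methyl to the chain carbon bound to the nitrogen, so that ethyl becomes isopropyl, gives a 1.4-fold higher number from compound 3 to compound 4 (0.15 log units; within the scatter), the first added carbon here that cannot be told apart from no change. Isopropyl still stands clear of the longer chains, with a 2.4-fold lower number from compound 2 to compound 4 (0.38 log units; beyond the scatter) and an 8.5-fold lower number from compound 1 to compound 4 (0.93 log units; beyond the scatter), so among these four compounds a branched group of this size fits with ethyl, while the higher numbers appear only with pentyl and 3-(4-methylphenoxy)propyl. Nothing shown here explains these numbers.

Still open, from the compounds shown here alone, is whether a single methyl on the nitrogen would give a lower number than ethyl, or how a chain ending in an amine or a carboxylic acid would behave. Also open, going by these compounds, is whether a cyclopentyl ring on this nitrogen would stay close to compound 3 and compound 4 or rise toward compound 2.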